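The source may hold more compounds than are shown below. What is called first, only, known or untested is meant among the compounds shown, and "the series" means these compounds.

Compound 3, `COC(=O)CCc1ccncc1-c1ccc2ccccc2c1`, is one of three closely related compounds examined in an assay on a protein complex for inhibition of CDK8/Cyclin C (Homo sapiens), with a stated time of 1 h (a lower number here means a stronger inhibitor, a higher number a weaker inhibitor), where compound 3 gives 259 nM. Of the two compounds that have a number in this assay, compound 3 stands highest. Its nearest neighbour, compound 2, `CN1CCN(C(=O)/C=C/c2ccncc2-c2ccc3ccccc3c2)CC1`, gives 43.6 nM in this assay, and the gap between them lies beyond the scatter. Compound 1, `CC(C)[C@@H](NC(=O)/C=C/c1ccncc1-c1ccc2ccccc2c1)C(=O)O`, gives "not determined" (no result reported) in this assay, so no number is available for it. Compound 4, `CCOC(=O)/C=C/c1ccncc1-c1ccc2ccccc2c1`, has not been measured yet; it differs from compound 3 in a single place: 2-(ethoxycarbonyl)ethenyl in place of 2-(methoxycarbonyl)ethyl on an aromatic carbon. Like compound 2, and unlike compound 3, compound 4 carries a double bond outside aromatic rings in the group attached to the shared core. For the measured compounds named here, no step between measured compounds covers this change, so any expectation rests on compound 2 alone. Compound 4 is expected to give a lower number than compound 3 in this assay, a step of moderate size, a 2.2-fold lower number from compound 3 to compound 4 (0.33 log units; beyond the scatter), because compound 2 gives 43.6 nM with a double bond outside aromatic rings in its own group. Compound 4 is therefore estimated at 120 nM, with a range from 40 nM to 400 nM.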

Compound 4, half-maximal inhibitory concentration: 53.3 nM
Beside the measured number, compound 4's estimate is 2.3-fold (0.35 log units) above it; measured number inside the range.
By their numbers in this assay, from the lowest: compounds 2 and 4 (each within the scatter of the next); then compound 3.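

In this assay, the step on this aromatic carbon, opposite the ring nitrogen, is a 4.9-fold lower number from compound 3 to compound 4 (0.69 log units; beyond the scatter), so replacing 2-(methoxycarbonyl)ethyl with 2-(ethoxycarbonyl)ethenyl changes the number by more than the scatter. On the carbonyl carbon, ethoxy in place of 4-methylpiperazin-1-yl gives a 1.2-fold higher number from compound 2 to compound 4 (0.09 log units; within the scatter), so compounds 2 and 4 cannot be told apart here, although only compound 2 has a ring in that group. Nothing available explains either result.

The first step combines the extra double bond with ethoxy in place of methoxy, and the compounds shown do not separate the two; 2-(ethoxycarbonyl)ethyl at this place would do so. Also open, going by these compounds, is how a primary amide or a nitrile at the end of the ethenyl chain would behave.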